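A few compounds are considered here, and "the series" means these few. Any claim that something is new, unique, unknown or untested is made for them only; others in the source may bear on it.

Compound 1 `O=C(O)c1nc(C2CCCCC2)n(-c2cccc(Cl)c2F)c1-c1ccc(F)c(Cl)c1`: in a functional assay on SAOS-2 cells (Homo sapiens) for antiproliferative activity, read by fluorescence, with a stated time of 72 h (on this read-out higher numbers stand for weaker inhibition and lower numbers for stronger inhibition), compound 1 gives > 30000 nM, which is a limit of the assay.
Compound 2 `Cc1nnc(-c2nc(C3CCCCC3)n(-c3cccc(Cl)c3F)c2-c2ccc(F)c(Cl)c2)o1`: in this assay compound 2 gives > 30000 nM, again a limit of the assay.

Compound 1 therefore stands only at a limit on the numbers shown, with no number of its own. Among the compounds with values here, the one measured step, 5-methyl-1,3,4-oxadiazol-2-yl in place of carboxy on an aromatic carbon, is a step that the two limits leave unreadable from compound 1 to compound 2, since both ends sit at the same limit (the limit of > 30000 nM in this assay, at which 2 of the 2 values shown sit).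

Compound 3 `O=C(O)c1nc(-c2ccccc2)n(-c2cccc(Cl)c2F)c1-c1ccc(F)c(Cl)c1` carries the change (phenyl in place of cyclohexyl on an aromatic carbon), placed on an aromatic carbon of a five-membered aromatic ring with 2 nitrogen, between two ring nitrogen atoms, next to the ring atom that bears a 3-chloro-2-fluorophenyl group. Within the data shown here, no measured step touches this position; the only step available, from compound 1 to compound 2, is unreadable. What the two limits show is that the shared core with carboxy or with the oxadiazole has not yet reached measurable inhibition in this assay.

Compound 3 is therefore expected to sit near the same limit, with the step from compound 1 estimated as a step that the limit leaves unreadable from compound 1 to compound 3. The estimate for compound 3 is 40000 nM, within 8000 nM to 200000 nM.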

Compound 3, half-maximal inhibitory concentration: > 30000 nM
Compound 3: only a limit was reported; the forecaster's own chance of this, stated with the estimate: 75%; the middle value is on the limit's open side.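

In this assay the change to phenyl in place of cyclohexyl gives no readable step, since compound 1 and compound 3 both stand only at a limit of the assay: the limit of > 30000 nM in this assay, at which 3 of the 3 values shown sit. The compounds shown leave open whether in this assay any group at these places on the shared core gives measurable inhibition.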